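Swapping an Ester Oxygen for Sulfur on a Phenolic Core

A few compounds are considered here, and "the series" means these few. Any claim that something is new, unique, unknown or untested is made for them only; others in the source may bear on it.

Compound 1, `COc1c(C)c(O)c(C)c(C(C)C)c1C(=O)SC`, gives a limit of the assay rather than a number in a functional assay on HCT-116 cells (Homo sapiens) for cytotoxicity, read by sulforhodamine B assay, with a stated time of 72 h; a lower number here means a stronger inhibitor, a higher number a weaker inhibitor: > 40000 nM.
Compound 2, `COC(=O)c1c(O)c(C)c(O)c(C)c1C(C)C`, gives 7300 nM in this assay.

Of the two results shown, compound 2 holds the only actual number in this assay, while the other result sits at the limit (the limit of > 40000 nM in this assay, at which 1 of the 2 values shown sits). Compound 2 is therefore the only anchor for what follows.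

Compound 3, `CSC(=O)c1c(O)c(C)c(O)c(C)c1C(C)C`, has not yet been measured in this assay. It is built from compound 2 by a single change: methylsulfanyl in place of methoxy on a carbonyl carbon. The rest of the shared core of compound 2 stays as it is.

Among the compounds with values here, no step between two measured compounds with this same change is available, so there is nothing to calibrate the size of the move against. A change this small, with the same count of heavy atoms and acceptors, is expected to shift potency little, and the step of a 1.4-fold higher number from compound 2 to compound 3 (0.14 log units; within the scatter) is expected to stay within or only modestly beyond the usual scatter. Compound 3 is accordingly estimated at 10000 nM, with a range from 3000 nM to 40000 nM.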

Compound 3, half-maximal inhibitory concentration: 3900 nM
Estimate against measurement, compound 3: 2.6-fold (0.41 log units) above; measured number inside the range.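

In this assay, methylsulfanyl in place of methoxy on a carbonyl carbon gives a 1.9-fold lower number from compound 2 to compound 3 (0.27 log units; within the scatter), so the two compounds cannot be told apart and this swap is tolerated at this position. Within the data shown here, the other change, hydrogen in place of methyl on an oxygen on an aromatic ring, gives an at least 10-fold lower number from compound 1 to compound 3 (1.01 log units; beyond the scatter), which separates a compound with a measured number from one without and is the only step here beyond the scatter. Compound 1 is a limit and not a number, so that step has only a bound and no exact size: the limit of > 40000 nM in this assay, at which 1 of the 3 values shown sits.

The compounds shown leave open what an amine or a longer chain in place of methylsulfanyl on the carbonyl carbon would do. They also leave open whether hydrogen in place of methyl on that oxygen has a similar effect when methoxy sits on the carbonyl carbon.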